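Methoxy for tert-butyl on compound 1: expected outcome

The compounds below may be only part of what the source reports. "The series", "measured", "known", "first", "only" and "open" are said of these compounds alone.

Measured compounds:
compound 1 `CC(C)(C)c1ccc(OCCCON2C(N)=NC(N)=NC23CCSCC3)cc1` — 1 nM
compound 2 `NC1=NC2(CCOCC2)N(OCCCOc2ccc(F)cc2)C(N)=N1` — 3280 nM
compound 3 `NC1=NC2(CCOCC2)N(OCCCOc2cc(Cl)c(Cl)cc2Cl)C(N)=N1` — 2750 nM

In a functional assay on HCT-116 cells (Homo sapiens) for antiproliferative activity, read by MTT assay, with a stated time of 72 h (a higher number here means a weaker inhibitor, a lower number a stronger inhibitor), compound 1 gives 1 nM, the lowest of the three numbers. Compound 3 gives 2750 nM and compound 2 gives 3280 nM; both lie far above compound 1, but both differ from it in the core as well as in the aryl group, so neither isolates the aryl substituent.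

For the measured compounds named here, the only measured single step, a 1.2-fold lower number from compound 2 to compound 3 (0.08 log units; within the scatter), exchanges the whole aryl group on the oxygen on a saturated carbon, on the other core, and lies within the scatter. It bears only loosely on the change now considered.

Compound 4 `COc1ccc(OCCCON2C(N)=NC(N)=NC23CCSCC3)cc1` carries the change (methoxy in place of tert-butyl on an aromatic carbon). Going by the values given here, no measured pair tests this exchange; the one step that exists left the number unchanged within the scatter. Compound 4 is therefore expected to stay close to compound 1, with room for a modest rise, at 8 nM, between 1.5 nM and 50 nM. The expected step is an 8.0-fold higher number from compound 1 to compound 4 (0.90 log units; beyond the scatter).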

Compound 4, half-maximal inhibitory concentration: 70 nM
Beside the measured number, compound 4's estimate is 8.8-fold (0.94 log units) below it; the whole stated range lies below it.
By their numbers in this assay, from the lowest: compound 1; then compound 4; then compounds 3 and 2 (each within the scatter of the next).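

In this assay, methoxy in place of tert-butyl on an aromatic carbon, para to a large group, gives a 70-fold higher number from compound 1 to compound 4 (1.85 log units; beyond the scatter). For the compounds shown here, on the core of compound 1, this place on the aromatic ring is therefore sensitive to the group it carries, which the only earlier step, a 1.2-fold lower number from compound 2 to compound 3 (0.08 log units; within the scatter), made on another core, did not reveal. The exchange replaces an all-carbon group with a smaller one containing oxygen, and no measurement here explains the size of the step or separates these two differences.

Still open, going by these compounds, is whether isopropyl, cyclopropyl or trifluoromethyl at this place would retain the number of compound 1, and how an amine or a carboxylic acid there would fare. Also unresolved is whether the same exchange would give a step of similar size on the core of compound 2.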